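Proline hydroxyl removal in a hydroxyproline-containing lipopeptide series

This account rests on a few compounds, and the source may have more. Where it says the series, first, only, none or still open, it means among the compounds named here.

Two compounds have numbers in a functional assay on P388 cells (Mus musculus) for cytotoxicity; a higher number here means a weaker inhibitor, a lower number a stronger inhibitor. Compound 1 `CCCCCCCC(=O)N(C)[C@@H](CC(C)C)C(=O)N[C@H](C(=O)N(C)[C@H](C(=O)N1C[C@@H](O)C[C@H]1C(=O)N1C(=O)C=C[C@@H]1C)C(C)C)C(C)OC(C)=O` gives 66.7 nM in this assay and stands as the lowest of the two numbers. Compound 2 `CCCCCCCC(=O)N(C)[C@@H](CC(C)C)C(=O)N[C@H](C(=O)N(C)[C@H](C(=O)N1C[C@@H](O)C[C@H]1C(=O)N1C(=O)C=C[C@H]1C)C(C)C)C(C)OC(C)=O` differs from compound 1 only in the configuration of a stereocentre at a saturated ring carbon. In this assay, for the measured compounds named here, compound 2 gives 7000 nM; the step of a 100-fold higher number from compound 1 to compound 2 (2.02 log units; beyond the scatter) is the only measured step in the set.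

Compound 3 `CCCCCCCC(=O)N(C)[C@@H](CC(C)C)C(=O)N[C@H](C(=O)N(C)[C@H](C(=O)N1CCC[C@H]1C(=O)N1C(=O)C=C[C@@H]1C)C(C)C)C(C)OC(C)=O` is the next member. Relative to compound 1 the change is hydrogen in place of hydroxy on a saturated ring carbon, while all stereocentres are kept as in compound 1. Going by the values given here, no measured step touches this place: the step from compound 1 to compound 2 concerns a stereocentre elsewhere in the shared core and gives no guide to the loss of the hydroxy group. With the configuration that gave the low number retained and a single hydroxy removed, the expected step of a 1.3-fold higher number from compound 1 to compound 3 (0.13 log units; within the scatter) is small, not clearly beyond the scatter, in either direction. Compound 3 is therefore estimated at 90 nM in this assay, with a range of 20 nM to 450 nM.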

Compound 3, half-maximal inhibitory concentration: 5000 nM
The estimate for compound 3 lay 56-fold (1.74 log units) below the measured number; the measured number lies above the stated range.
By their numbers in this assay, from the lowest: compound 1; then compounds 3 and 2 (each within the scatter of the next).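

In this assay, the hydroxy on the saturated ring carbon, two ring bonds from the ring nitrogen, turns out to be a sensitive place: hydrogen in its stead gives a 75-fold higher number from compound 1 to compound 3 (1.87 log units; beyond the scatter), a large step from a single-atom change. The set now holds two single changes from compound 1 that each give a large step, the other being a 100-fold higher number from compound 1 to compound 2 (2.02 log units; beyond the scatter), so the low number of compound 1 is lost on either change, and keeping the stereocentres as in compound 1 does not preserve it once the hydroxy has gone. Nothing on record bears on why this hydroxy matters.

Open, from the compounds shown here alone, is whether the hydroxy itself is required on this ring carbon, or whether another group there, such as a methoxy, an amine or a fluorine atom, or the hydroxy drawn in the opposite configuration, would hold the number of compound 1. Also open, going by these compounds, is what removal of the hydroxy does when the stereocentre changed in compound 2 carries its other configuration, and whether the two changes add up at all.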